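Replacing a phenolic hydroxy with methoxy on compound 2

The compounds below may be only part of what the source reports. "The series", "measured", "known", "first", "only" and "open" are said of these compounds alone.

Of the compounds shown here, three have been measured so far in a functional assay on HSC-3 cells (Homo sapiens) for cytotoxicity; on this read-out lower numbers stand for higher toxicity in this test and higher numbers for lower toxicity in this test. Compound 1 `COc1cc(/C=C2\CC/C(=C\c3ccc([N+](=O)[O-])cc3)C2=O)cc(OC)c1OC` reaches only the limit of this test: in this assay compound 1 gives > 400000 nM, which is a limit and not a number. Among the measured compounds shown here, compound 2 `COc1cc(/C=C2\Cc3ccccc3/C(=C\c3ccc([N+](=O)[O-])cc3)C2=O)ccc1O` is the one this step starts from; in this assay compound 2 gives 3800 nM. Compound 3 `COc1ccc(/C=C2\CCC/C(=C\c3ccc([N+](=O)[O-])cc3)C2=O)cc1OC` carries a 3,4-dimethoxyphenyl group on a different core, and in this assay compound 3 gives 4400 nM, a number that lies within the usual scatter of the value of compound 2.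

Compound 4 `COc1ccc(/C=C2\Cc3ccccc3/C(=C\c3ccc([N+](=O)[O-])cc3)C2=O)cc1OC` is built from compound 2 by a single change: methyl in place of hydrogen on an oxygen on an aromatic ring. The result is the same 3,4-dimethoxyphenyl group that compound 3 carries, now on the core of compound 2. For the measured compounds named here, no measured pair shows exactly this change, so the expectation rests on compound 3 and its value 4400 nM being close to that of compound 2. The expected step from compound 2 to compound 4 is a 1.3-fold higher number from compound 2 to compound 4 (0.12 log units; within the scatter), a shift that is expected to stay within the scatter. Compound 4 is therefore estimated to give 5000 nM, with a range from 1800 nM to 14000 nM.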

Compound 4, half-maximal cytotoxic concentration: 4200 nM
The estimate for compound 4 lay 1.2-fold (0.08 log units) above the measured number; the range from low to high includes it.
By their numbers in this assay, from the lowest: compounds 2, 4 and 3 (each within the scatter of the next). At a limit, above all of these: compound 1.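

In this assay, the change from 4-hydroxy-3-methoxyphenyl to 3,4-dimethoxyphenyl on the shared core gives a 1.1-fold higher number from compound 2 to compound 4 (0.04 log units; within the scatter), so this test does not tell the hydroxy group from the methoxy group at this position. Among the compounds shown here, earlier, the 3,4-dimethoxyphenyl group could be seen only on the different core of compound 3, whereas this pair isolates the single change on one core. Compound 1 alone sits at a limit of the test, so this step compares two real numbers: the limit of > 400000 nM in this assay, at which 1 of the 4 values shown sits.

From the compounds shown here alone, whether the position stays as tolerant with a larger group on this oxygen, such as a longer chain like butoxy, or with an amine or a carboxylic acid in place of the hydroxy, remains open. Also open, going by these compounds, is whether hydroxy to methoxy gives the same result on the cores of compound 1 and compound 3.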